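Fluoro to methoxy on the fused ring: cytotoxicity note

The source may hold more compounds than are shown below. What is called first, only, known or untested is meant among the compounds shown, and "the series" means these compounds.

Compound 3 `O=[N+]([O-])c1ccc(-c2nnc(-c3cccnc3)n2Nc2nc3ccc(F)cc3s2)cc1` is known in an ADME assay on MT4 cells (Homo sapiens) for cytotoxicity, read by MTT assay, with a stated time of 5 days (on this read-out higher numbers stand for lower toxicity in this test and lower numbers for higher toxicity in this test), only as a limit, >= 108 ug/mL, and stands at the limit of >= 108 ug/mL in this assay, at which 1 of the 3 values shown sits. Among the smaller members of the series, compound 1 `NNc1nc2ccc(F)cc2s1` gives 13.8 ug/mL and compound 2 `Cc1ccc2nc(NN)sc2c1` gives 4.52 ug/mL, and the change of methyl in place of fluoro on an aromatic carbon produced a 3.1-fold lower number from compound 1 to compound 2 (0.48 log units; beyond the scatter). Compound 4 `COc1ccc2nc(Nn3c(-c4ccc([N+](=O)[O-])cc4)nnc3-c3cccnc3)sc2c1` differs from compound 3 by methoxy in place of fluoro on an aromatic carbon. Going by the values given here, the only measured step that touches the same position, the methyl replacement from compound 1 to compound 2, is a different group and was only modest, so no clear direction is assumed for methoxy; since compound 3 sits at the limit, a further rise would remain unmeasurable, and a fall of the size seen earlier would still leave a high number. Compound 4 is therefore expected near the top of the range, with the estimated step of an at least 1.2-fold lower number from compound 3 to compound 4 (0.07 log units; that floor lies within the scatter) and an estimated value of 90 ug/mL, between 30 ug/mL and 300 ug/mL.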

Compound 4, half-maximal cytotoxic concentration: 12.9 ug/mL
Estimate against measurement, compound 4: 7.0-fold (0.84 log units) above; measured number outside the range, below it.
By their numbers in this assay, from the lowest: compound 2; then compounds 4 and 1 (each within the scatter of the next). At a limit, above all of these: compound 3.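

In this assay, replacing fluoro on this aromatic carbon also matters in the full compound, not only in the small members of the series: the step is an at least 8.3-fold lower number from compound 3 to compound 4 (0.92 log units; beyond the scatter). Taken with a 3.1-fold lower number from compound 1 to compound 2 (0.48 log units; beyond the scatter), both listed replacements of fluoro on this carbon lower the number, and no compound shown goes against this, although the two pairs carry different entering groups and different remaining structures. Compound 3 is held only at a limit, so the new step gives a floor and not a full size: the limit of >= 108 ug/mL in this assay, at which 1 of the 4 values shown sits.

The compounds shown leave open whether the lower number follows the loss of fluoro or the entry of methoxy, and a chloro or an amine on this carbon would help separate the two. They also leave open how methyl would read in the full compound.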